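Replacing a methoxypiperidine with a spirocyclic amine: solubility outlook

This account rests on a few compounds, and the source may have more. Where it says the series, first, only, none or still open, it means among the compounds named here.

Measured compounds in a physicochemical assay for solubility, read by spectrophotometry, in phosphate buffer, with a stated time of 2 h, at pH 7.4; on this read-out lower numbers stand for lower solubility and higher numbers for higher solubility:
Compound 1 `COc1ccc2[nH]c(C(=O)N3CC(=O)N(Cc4ccccc4)[C@@H](CN4CCC(OC)CC4)C3)cc2c1` gives > 25000 nM, which is a limit of the assay and not a number.
Compound 2 `COc1ccc2[nH]c(C(=O)N3CC(=O)N(Cc4cccc(OC)n4)[C@@H](Cc4ccccc4)C3)cc2c1` gives 47500 nM.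
Compound 3 `COc1cccc(CN2C(=O)CN(C(=O)c3cc4cc(OC)ccc4[nH]3)C[C@@H]2CCc2ccccc2)c1` gives 5100 nM.

Compound 1 therefore stands only at a limit in this assay, and the limit of > 25000 nM in this assay, at which 1 of the 3 values shown sits, is all that is known of it. Compound 4 `COc1ccc2[nH]c(C(=O)N3CC(=O)N(Cc4ccccc4)[C@@H](CN4CCC5(CCCC5)CC4)C3)cc2c1` differs from compound 1 by a group of 10 heavy atoms (9 carbon, 1 nitrogen; one five-membered non-aromatic ring of carbon only, one six-membered non-aromatic ring with 1 hetero atom) in place of a group of 8 heavy atoms (6 carbon, 1 nitrogen, 1 oxygen; one six-membered non-aromatic ring with 1 hetero atom), on a saturated chain carbon bound to a saturated ring carbon. Among the compounds with values here, no measured pair shows this change, so any expectation rests on the structures alone. The step from compound 1 to compound 4, an at least 2.7-fold lower number from compound 1 to compound 4 (0.44 log units; beyond the scatter), is expected to run toward lower solubility and to exceed the usual scatter. Compound 4 is estimated at 9000 nM, with a range from 2500 nM to 30000 nM.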

Compound 4, solubility: 5000 nM
Beside the measured number, compound 4's estimate is 1.8-fold (0.26 log units) above it, and the stated range covers the measured number.
By their numbers in this assay, from the lowest: compounds 4 and 3 (each within the scatter of the next); then compound 2.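

Within the data shown here, the first measured pair at this position shows that, in this assay, the spirocyclic amine in place of 4-methoxypiperidin-1-yl, on a saturated chain carbon bound to a saturated ring carbon, goes with an at least 5.0-fold lower number from compound 1 to compound 4 (0.69 log units; beyond the scatter) and not with a change inside the scatter. Compound 1 gives a limit and not a number, which leaves the full size of this step unknown: the limit of > 25000 nM in this assay, at which 1 of the 4 values shown sits.

The compounds shown do not separate the loss of the ring-bound methoxy group from the gain of the five-membered carbon ring. On these data alone, how a morpholine or a 4-hydroxypiperidine would read at this place also remains open.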